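Replacing the aryl group on the thiourea nitrogen of compound 2

The compounds below may be only part of what the source reports. "The series", "measured", "known", "first", "only" and "open" are said of these compounds alone.

Compound 2 (`O=C1Nc2ccc([N+](=O)[O-])cc2/C1=N/NC(=S)Nc1ccc(Br)cc1`) stands lowest of the two numbers in a functional assay on the whole organism for inhibition, with Lemna aequinoctialis as the target, tested at 100 ug/mL (a higher number here means more inhibition of growth at the concentration tested, a lower number less inhibition of growth), giving 15%; the nearest is compound 1 (`Cc1cccc(NC(=S)N/N=C2\C(=O)Nc3ccc([N+](=O)[O-])cc32)c1`), which in this assay gives 20%. Among the compounds with values here, the one step between them, a number 5 percentage points lower from compound 1 to compound 2 (within the scatter), stayed within the scatter. Compound 3 (`N#Cc1cccc(NC(=S)N/N=C2\C(=O)Nc3ccc([N+](=O)[O-])cc32)c1`) differs from compound 2 by 3-cyanophenyl in place of 4-bromophenyl on an amide-type nitrogen. Within the data shown here, the only measured step exchanged one aryl group on that nitrogen for another without any change beyond the scatter, so for compound 3 the expected step in this assay is a number 3 percentage points higher from compound 2 to compound 3 (within the scatter), none beyond the scatter. Compound 3 is therefore estimated at 18%, with a range from 5% to 32%.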

Compound 3, percent growth inhibition at one concentration: 15%
The estimate for compound 3 lay 3 percentage points above the measured number; the range from low to high includes it.
By their numbers in this assay, from the lowest: compounds 2, 3 and 1 (each within the scatter of the next).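

In this assay, 3-cyanophenyl in place of 4-bromophenyl on the amide-type nitrogen gave no change at the digits printed from compound 2 to compound 3 (within the scatter). Cyano in place of methyl on the aromatic carbon gave a number 5 percentage points lower from compound 1 to compound 3 (within the scatter). The nitrile-bearing aryl group thus stays within the scatter of both aryl groups seen before, and no pair among these three compounds separates, while nothing measured here speaks to the reason for these numbers.

The compounds shown leave open whether a carboxylic acid or an amine on this aryl ring, or a longer alkyl chain in its place on the nitrogen, would move the number beyond the scatter.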